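An Ethyl Group Replaces the (Pyrrolidin-1-yl)carbonyl

The source may report more compounds than this note shows. Statements on the series, on what has been measured and on what is new or still open speak of the compounds shown alone.

In a functional assay on U-87MG ATCC cells for cytotoxicity against U-87 MG (Homo sapiens), read by MTT assay, with a stated time of 72 h (on this read-out higher numbers stand for weaker inhibition and lower numbers for stronger inhibition), compound 1 `COc1ncc(-c2ccc3nc(NC(=O)NCC(=O)N4CCCCC4)nn3c2)cc1NS(=O)(=O)c1ccc(F)cc1` gives 740 nM, compound 2 `COc1ncc(-c2ccc3nc(NC(=O)NCCN4CCCCC4)nn3c2)cc1NS(=O)(=O)c1ccc(F)cc1` gives 1080 nM and compound 3 `COc1ncc(-c2ccc3nc(NC(=O)NCC(=O)N4CCCC4)nn3c2)cc1NS(=O)(=O)c1ccc(F)cc1` gives 1000 nM. Compound 3 thus stands level with the other two, as shown by a 1.4-fold higher number from compound 1 to compound 3 (0.13 log units; within the scatter) and a 1.1-fold lower number from compound 2 to compound 3 (0.03 log units; within the scatter). The remaining step is a 1.5-fold higher number from compound 1 to compound 2 (0.16 log units; within the scatter).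

Compound 4 `CCCNC(=O)Nc1nc2ccc(-c3cnc(OC)c(NS(=O)(=O)c4ccc(F)cc4)c3)cn2n1` carries ethyl in place of (pyrrolidin-1-yl)carbonyl on a saturated chain carbon bound to an amide-type nitrogen. The measured steps only exchange one ring-bearing group for another, and none removes the ring, so they offer limited guidance. The expected change in this assay is a 1.3-fold lower number from compound 3 to compound 4 (0.10 log units; within the scatter), with no shift beyond the scatter anticipated. For compound 4 the estimate is 800 nM, with an expected range of 250 nM to 2500 nM.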

Compound 4, half-maximal inhibitory concentration: 420 nM
Compound 4: middle estimate off by 1.9-fold (0.28 log units), on the high side, and the stated range covers the measured number.
By their numbers in this assay, from the lowest: compounds 4, 1, 3 and 2 (each within the scatter of the next, the first and the last beyond it).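

In this assay, among these compounds, replacing the ring-bearing end group with a plain chain on a saturated chain carbon bound to an amide-type nitrogen gives the first steps at this position beyond the scatter, both modest (a 2.4-fold lower number from compound 3 to compound 4 (0.38 log units; beyond the scatter) and a 2.6-fold lower number from compound 2 to compound 4 (0.41 log units; beyond the scatter)). The step from the piperidine amide stays within the scatter (a 1.8-fold lower number from compound 1 to compound 4 (0.25 log units; within the scatter)), so the pattern does not hold against compound 1, but compound 4 shows that no ring is needed here for this level of activity. Nothing at hand explains the difference. As far as these compounds go, whether a longer chain than propyl, or a propyl chain carrying a hydroxyl group or a carboxylic acid, would match compound 4 stays open.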